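Cytotoxicity notes: fluoropyridyl for fluorophenyl on the shared core

This account rests on a few compounds, and the source may have more. Where it says the series, first, only, none or still open, it means among the compounds named here.

Within the data shown here, compound 2 `O=C(Nc1ccc(F)c(-c2nc3ncc(-c4cccc(F)c4)cc3[nH]2)c1)N1CCCC1` is the only member of the set with a plain number in an ADME assay on HepG2 cells (Homo sapiens) for cytotoxicity, read by resazurin assay, with a stated time of 48 h; a higher number here means that more compound is needed for the effect, a lower number that less compound is needed: compound 2 gives 28200 nM. For compound 1 `Cc1nc(C)c(C(=O)Nc2ccc(F)c(-c3nc4ncc(-c5cccnc5Cl)cn4n3)c2)o1` the assay reports only a limit, > 50000 nM. For compound 3 `O=C(Nc1ccc(F)c(-c2nc3ncc(-c4cncc(F)c4)cc3[nH]2)c1)N1CCCC1` the assay likewise reports only a limit, > 50000 nM. Among the measured compounds shown here, two of the three results therefore sit at the limit of > 50000 nM in this assay, at which 2 of the 3 values shown sit, so compound 2 stands alone as the one compound with a measured concentration, with nothing to rank it against.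

Compound 4 `O=C(Nc1ccc(F)c(-c2nc3ncc(-c4ccc(F)nc4)cc3[nH]2)c1)N1CCCC1` is not yet measured. It differs from compound 2 in one place (6-fluoropyridin-3-yl in place of 3-fluorophenyl on an aromatic carbon). For the measured compounds named here, the one measured step that bears on this is the exchange of the same 3-fluorophenyl for a different fluoropyridyl group, an at least 1.7-fold higher number from compound 2 to compound 3 (0.24 log units; that floor lies within the scatter). That step points, if anywhere, toward a higher number, but its floor lies within the scatter, so its true size is not known.

For compound 4 in this assay a step of the same kind is expected, a 1.6-fold higher number from compound 2 to compound 4 (0.20 log units; within the scatter), upward rather than downward, with a real chance that the assay again reports only a limit. Compound 4 is accordingly estimated at 45000 nM, with a range from 20000 nM to 100000 nM.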

Compound 4, half-maximal effective concentration: > 50000 nM
Compound 4: only a limit was reported; the forecaster's own chance of this, stated with the estimate: 55%; at least 1.1-fold (0.04 log units) between middle value and limit.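

In this assay, a second fluoropyridyl group at this place on the shared core behaves as the first did, with 6-fluoropyridin-3-yl in place of 3-fluorophenyl giving an at least 1.7-fold higher number from compound 2 to compound 4 (0.24 log units; that floor lies within the scatter); the floor of this step, like that of the step to compound 3, lies within the scatter, so the direction holds for both listed fluoropyridyl groups but neither step has a known size. Compound 3 and compound 4 both stand as limits, so the step between them cannot be read, and the two placements of the ring nitrogen cannot be told apart in this assay. The set now rests largely on one limit: the limit of > 50000 nM in this assay, at which 3 of the 4 values shown sit.

Among these compounds, compound 2, at 28200 nM, remains the only plain number, so how far either fluoropyridyl group really moves the value stays unknown. Also open, as far as these compounds go, is whether a group of another kind at this place, such as a carboxylic acid, an aminomethyl group or an unsubstituted pyridin-3-yl, would give a plain number, and on which side of compound 2 it would fall.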